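A Methyl Added to the Stronger Stereoisomer

This account rests on a few compounds, and the source may have more. Where it says the series, first, only, none or still open, it means among the compounds named here.

Of the compounds shown here, three built on one shared core have been tested in an ADME assay on the whole organism for inhibition, with Echinochloa crus-galli var. formosensis as the target, with a stated time of 4 days; a higher number here means a weaker inhibitor, a lower number a stronger inhibitor. Compound 1 `CC[C@H](C)Nc1nc(Cl)nc(N[C@@H](C)c2ccccc2)n1` gives 14100 nM. Compound 2 `CC(C)Nc1nc(Cl)nc(N[C@@H](C)c2ccccc2)n1` gives 11000 nM. Compound 3 `CC(C)Nc1nc(Cl)nc(N[C@H](C)c2ccccc2)n1` gives 2000 nM, the lowest of the three numbers, which makes it the strongest inhibitor among them.

Two changes link these compounds. From compound 2 to compound 1 the change is methyl in place of hydrogen on a saturated chain carbon, two bonds along the chain from a nitrogen on an aromatic ring, and the step is a 1.3-fold higher number from compound 2 to compound 1 (0.11 log units; within the scatter). From compound 2 to compound 3 nothing is added or removed: the two compounds have the same atoms and bonds and differ only in configuration as drawn: 1 of 1 stereo elements differ; a stereocentre at a saturated chain carbon is drawn S in compound 2 and R in compound 3. Here the step is a 5.5-fold lower number from compound 2 to compound 3 (0.74 log units; beyond the scatter), and it rests on the fact that compounds 2 and 3 differ only in the configuration as drawn alone.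

Compound 4 `CC[C@@H](C)Nc1nc(Cl)nc(N[C@H](C)c2ccccc2)n1` has not yet been measured. It stands to compound 3 as compound 1 stands to compound 2: the change is methyl in place of hydrogen on a saturated chain carbon, two bonds along the chain from a nitrogen on an aromatic ring, at the same place as before, so it is the same change applied to the other stereoisomer. Among the four compounds this change appears twice in all.

Because the same change from compound 2 to compound 1 moved the number by only a 1.3-fold higher number from compound 2 to compound 1 (0.11 log units; within the scatter), a step of similar size is expected here, and the estimated step is a 1.3-fold higher number from compound 3 to compound 4 (0.11 log units; within the scatter). In this assay compound 4 is expected to give about 2600 nM, with a likely range from 1200 nM to 6000 nM.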

Compound 4, half-maximal inhibitory concentration: 4570 nM
Estimate against measurement, compound 4: 1.8-fold (0.24 log units) below; the measured number falls inside the stated range.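

In this assay, among these compounds, the same change from isopropyl to sec-butyl on the stronger stereoisomer gives a 2.3-fold higher number from compound 3 to compound 4 (0.36 log units; beyond the scatter), and this step agrees with the earlier one, so the change carries from one stereoisomer to the other about as well as two pairs can show: the same change on two cores in this assay, a 1.3-fold higher number (0.11 log units; within the scatter) from compound 2 to compound 1 and a 2.3-fold higher number (0.36 log units; beyond the scatter) from compound 3 to compound 4, 1.8-fold (0.25 log units) apart, within the scatter of two such steps The mirror-image pair gives a 3.1-fold lower number from compound 1 to compound 4 (0.49 log units; beyond the scatter), so the stereoisomers keep the same order once sec-butyl is in place, as they did with isopropyl: the fact that compounds 1 and 4 differ only in the configuration as drawn This does not establish a general rule, since it rests on only two pairs, one step lying within the scatter and the other beyond it, and since both stereocentres invert together between compound 1 and compound 4, that step cannot be assigned to either one alone.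

Still open, as far as these compounds go, is how the two stereocentres behave when they are paired the other way round, with the sec-butyl centre inverted while the other stays as it is in compound 4. From the compounds shown here alone, it is also open whether the same agreement between stereoisomers would hold for a longer chain such as n-pentyl, or for a chain carrying a hydroxyl group or a carboxylic acid.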